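A Selenium-for-Sulfur Swap Carried onto a Second Core

The compounds below may be only part of what the source reports. "The series", "measured", "known", "first", "only" and "open" are said of these compounds alone.

Compound 1, `CS/C(=N\C(=O)c1sccc1Cl)NC(=O)c1sccc1Cl`: in a functional assay on K562 cells (Homo sapiens) for cytotoxicity, read by MTT assay, with a stated time of 72 h (on this read-out lower numbers stand for higher toxicity in this test and higher numbers for lower toxicity in this test), compound 1 gives > 100000 nM, which is a limit of the assay.
Compound 2, `CS/C(=N\C(=O)c1cc(-c2ccccc2)nc2ccccc12)NC(=O)c1cc(-c2ccccc2)nc2ccccc12`: in this assay compound 2 gives > 100000 nM, again a limit of the assay.
Compound 3, `C[Se]/C(=N\C(=O)c1cc(-c2ccccc2)nc2ccccc12)NC(=O)c1cc(-c2ccccc2)nc2ccccc12`: in this assay compound 3 gives 73100 nM.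

Compound 3 arises from compound 2 by one change, (a group of 2 heavy atoms (1 carbon, 1 selenium; no ring) in place of a group of 2 heavy atoms (1 carbon, 1 sulfur; no ring), on a carbon with a double bond to nitrogen). The measured result is an at least 1.3-fold lower number from compound 2 to compound 3 (0.13 log units; that floor lies within the scatter). Because compound 2 sits at the assay limit, (the limit of > 100000 nM in this assay, at which 2 of the 3 values shown sit), only a floor for that step is known, and that floor lies within the usual scatter.

Compound 4, `C[Se]/C(=N\C(=O)c1sccc1Cl)NC(=O)c1sccc1Cl`, has not yet been measured in this assay. It carries the same kind of change onto the core of compound 1: a group of 2 heavy atoms (1 carbon, 1 selenium; no ring) in place of a group of 2 heavy atoms (1 carbon, 1 sulfur; no ring), on a carbon with a double bond to nitrogen. How the core of compound 1 differs from that of compound 2 is not broken down here.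

Going by the values given here, for compound 4 a step of a number no higher from compound 1 to compound 4 (the limit leaves the size open) is expected, because the one measured instance of this change gave an at least 1.3-fold lower number from compound 2 to compound 3 (0.13 log units; that floor lies within the scatter). Compound 4 is therefore estimated at 100000 nM, between 40000 nM and 300000 nM, with a fair chance that only a limit is reported.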

Compound 4, concentration lethal to 50% of the cells: 90000 nM
Estimate against measurement, compound 4: 1.1-fold (0.05 log units) above; low and high end bracket the measured number.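

In this assay, putting the selenium counterpart in place of methylsulfanyl on the core of compound 1 gives an at least 1.1-fold lower number from compound 1 to compound 4 (0.04 log units; that floor lies within the scatter). With the change now seen on two cores, the comparison stands as follows: the same change on two cores in this assay, an at least 1.3-fold lower number (0.13 log units; that floor lies within the scatter) from compound 2 to compound 3 and an at least 1.1-fold lower number (0.04 log units; that floor lies within the scatter) from compound 1 to compound 4; the limit leaves it open whether they differ On both cores the selenium compound gives a measured number where its methylsulfanyl parent gives only a limit, but this does not show that the change truly lowers the number or that it carries over with the same size, because both steps rest on that limit: the limit of > 100000 nM in this assay, at which 2 of the 4 values shown sit.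

The compounds shown leave open how a longer chain on the selenium, such as an ethyl group, or an amine on the same carbon would read in this assay. They also leave open whether the swap would give a step of definite size on a core whose methylsulfanyl compound gives a measured number rather than a limit.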